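This account rests on a few compounds, and the source may have more. Where it says the series, first, only, none or still open, it means among the compounds named here.

Compound 2 `Cc1ccc(-c2cc(/C=C/c3ccc(C(=O)NO)cc3)ccn2)c(F)c1` gives 15 nM in an assay on isolated protein for inhibition of protein deacetylase HDAC6 (Homo sapiens), read by fluorescence, with a stated time of 15 min (a lower number here means a stronger inhibitor, a higher number a weaker inhibitor), the lower of the two numbers measured, the other belonging to compound 1 `COc1ccccc1-c1cc(/C=C/c2ccc(C(=O)NO)cc2)ccn1`, which gives 28 nM. Among the compounds with values here, the only measured step, a 1.9-fold lower number from compound 1 to compound 2 (0.27 log units; within the scatter), exchanges one aryl group for another. Compound 3 `O=C(NO)c1ccc(/C=C/c2ccncc2)cc1` instead removes the aryl group altogether: hydrogen in place of 2-fluoro-4-methylphenyl on an aromatic carbon. Within the data shown here, no measured step tracks such a removal, so the expectation rests on the size of the group lost rather than on a comparable change. A weaker result is expected, with the step from compound 2 to compound 3 estimated as a 6.7-fold higher number from compound 2 to compound 3 (0.82 log units; beyond the scatter). Compound 3 is estimated at 100 nM, in the range 30 nM to 400 nM.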

Compound 3, half-maximal inhibitory concentration: 130 nM
Estimate against measurement, compound 3: 1.3-fold (0.11 log units) below; the measured number falls inside the stated range.
By their numbers in this assay, from the lowest: compounds 2 and 1 (each within the scatter of the next); then compound 3.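

Taking the aryl group off this carbon, next to the ring nitrogen, gives an 8.7-fold higher number from compound 2 to compound 3 (0.94 log units; beyond the scatter) and likewise a 4.6-fold higher number from compound 1 to compound 3 (0.67 log units; beyond the scatter) in this assay. Where exchanging one aryl group for another stayed within the scatter, either aryl group here goes with a lower number than hydrogen, so the larger change lies in having an aryl group at all. No evidence at hand gives a reason for this difference. As far as these compounds go, what remains open is whether a methyl group, an amine or a saturated cyclohexyl ring on this carbon would stand nearer compound 2 or compound 3.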